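This account rests on a few compounds, and the source may have more. Where it says the series, first, only, none or still open, it means among the compounds named here.

Measured in a functional assay on K562 cells (Homo sapiens) for antiproliferative activity, with a stated time of 72 h; on this read-out lower numbers stand for stronger inhibition and higher numbers for weaker inhibition:
- Compound 1 `CCCCC#Cc1cc([C@@H]2O[C@H](CO)[C@@H](O)[C@H]2O)n2ncnc(N)c12`: 2400 nM
- Compound 2 `Nc1ncnn2c([C@@H]3O[C@H](CO)[C@@H](O)[C@H]3O)cc(-c3ccccc3)c12`: > 100000 nM (a limit)
- Compound 3 `Nc1ncnn2c([C@@H]3O[C@H](CO)[C@@H](O)[C@H]3O)cc(-c3ccc(F)cc3)c12`: > 100000 nM (a limit)

Compound 3 has only a limit and no number, the same limit as compound 2: the limit of > 100000 nM in this assay, at which 2 of the 3 values shown sit.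

Compound 4 `Nc1ncnn2c([C@@H]3O[C@H](CO)[C@@H](O)[C@H]3O)cc(/C=C/c3ccccc3)c12` carries 2-phenylethenyl in place of 4-fluorophenyl on an aromatic carbon.

The closest evidence is an at least 41-fold higher number from compound 1 to compound 2 (1.61 log units; beyond the scatter) and an at least 41-fold higher number from compound 1 to compound 3 (1.61 log units; beyond the scatter), both large and beyond the scatter. The step that the two limits leave unreadable from compound 2 to compound 3 adds nothing readable. The entering group keeps an aromatic ring and adds a double bond, so only a modest move towards lower numbers is expected, and a result at the limit remains likely. The expected change is an at least 1.6-fold lower number from compound 3 to compound 4 (0.22 log units; that floor lies within the scatter). For compound 4 the estimated value is 60000 nM, with an expected range of 10000 nM to 100000 nM.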

Compound 4, half-maximal inhibitory concentration: 3100 nM
Compound 4: middle estimate off by 19-fold (1.29 log units), on the high side; measured number outside the range, below it.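

Placed on this aromatic carbon of the five-membered ring, a phenyl ring held one double bond away from the core gives a measurable value in this assay, with an at least 32-fold lower number from compound 3 to compound 4 (1.50 log units; beyond the scatter) and an at least 32-fold lower number from compound 2 to compound 4 (1.50 log units; beyond the scatter). Compounds 2 and 3 are held at a limit of the assay, not at a number: the limit of > 100000 nM in this assay, at which 2 of the 4 values shown sit. The 2-phenylethenyl group and the hex-1-yn-1-yl group are not separated, with a 1.3-fold higher number from compound 1 to compound 4 (0.11 log units; within the scatter).

The compounds shown leave open whether the double bond itself is needed, which a saturated 2-phenylethyl chain or a 2-phenylethynyl group in its place would test.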